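Cytotoxicity of a hydrazide pair: methyl to methoxy

A few compounds are considered here, and "the series" means these few. Any claim that something is new, unique, unknown or untested is made for them only; others in the source may bear on it.

This study covers a small set of compounds sharing one core and differing only in the group on the terminal aromatic ring. Compound 1 `Cc1ccc(/C=C/C(=O)NNC(=O)c2ccc3c(c2)OCCO3)cc1` and compound 2 `Cc1ccccc1/C=C/C(=O)NNC(=O)c1ccc2c(c1)OCCO2` have been tested in an ADME assay on cells (Macrophage) for cytotoxicity, read by MTT assay, with a stated time of 24 h; a lower number here means that less compound is tolerated, a higher number that more compound is tolerated; compound 1 gives 332000 nM and compound 2 gives 268000 nM. Compound 1 sits at one end of the two numbers shown, but the step of a 1.2-fold lower number from compound 1 to compound 2 (0.09 log units; within the scatter) shows that the two values are indistinguishable within the scatter. Compound 3 `COc1ccc(/C=C/C(=O)NNC(=O)c2ccc3c(c2)OCCO3)cc1` has not yet been measured. It differs from compound 1 in one place: methoxy in place of methyl on an aromatic carbon. Within the data shown here, the only measured step, from compound 1 to compound 2, also changes this terminal ring and leaves the number essentially unmoved, so for compound 3 no step beyond the scatter is expected, with a 1.1-fold lower number from compound 1 to compound 3 (0.04 log units; within the scatter). Compound 3 is therefore estimated at 300000 nM, in a range from 150000 nM to 600000 nM.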

Compound 3, half-maximal cytotoxic concentration: 319000 nM
For compound 3 the middle estimate is 1.1-fold (0.03 log units) below the measured one, and the stated range covers the measured number.
By their numbers in this assay, from the lowest: compounds 2, 3 and 1 (each within the scatter of the next).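

In this assay, putting methoxy in place of methyl on this aromatic carbon, para to a large group, gives a 1.0-fold lower number from compound 1 to compound 3 (0.02 log units; within the scatter), so here the exchange of 4-methylphenyl for 4-methoxyphenyl, which brings in an oxygen and one hydrogen-bond acceptor, cannot be told from no effect. The remaining pair tells the same story: a 1.2-fold higher number from compound 2 to compound 3 (0.08 log units; within the scatter), so 2-methylphenyl and 4-methoxyphenyl cannot be separated in this reading either. No measurement at hand offers an explanation for these closely matching numbers.

Still open, going by these compounds, is whether an amine, a carboxylic acid or a longer chain such as butoxy at this position would shift the number beyond the scatter. Also open, on these data alone, is whether 2-methoxyphenyl would match 4-methoxyphenyl in the same way.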